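The compounds below may be only part of what the source reports. "The series", "measured", "known", "first", "only" and "open" are said of these compounds alone.

The measured compounds and their values in a physicochemical assay for lipophilicity; on this read-out lower numbers stand for lower lipophilicity and higher numbers for higher lipophilicity:

compound 1 `NC(=O)C[C@H](NC(=O)c1ccc(C#Cc2ccccc2)cc1)C(=O)NO`: 1
compound 2 `CC(NC(=O)c1ccc(C#Cc2ccccc2)cc1)C(=O)NO`: > 3
compound 3 `O=C(NC1(C(=O)NO)CCOCC1)c1ccc(C#Cc2ccccc2)cc1`: > 4

All three share the same core and differ only in the group that carries the hydroxamic acid end. Within the data shown here, compound 1 is the only one with a plain number: in this assay compound 1 gives 1. For compound 2 the assay reports no number but a limit, > 3 (the limit of > 3 in this assay, at which 1 of the 3 values shown sits). For compound 3 the assay likewise reports only a limit, > 4 (the limit of > 4 in this assay, at which 1 of the 3 values shown sits). Compound 1 therefore stands as the sole fixed point among the three.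

Compound 4 `CS(=O)(=O)C[C@H](NC(=O)c1ccc(C#Cc2ccccc2)cc1)C(=O)NO` has not been measured. It differs from compound 1 in one place: methylsulfonyl in place of carbamoyl on a saturated chain carbon, two bonds along the chain from an amide-type nitrogen and a carbonyl carbon. Among the measured compounds shown here, no measured pair mirrors this change, so the expectation rests on compound 1 alone. The expected step, a number 0.20 log units higher from compound 1 to compound 4 (within the scatter), is small and would not clearly leave the usual scatter. Compound 4 is expected to give about 1.2, with a range from 0.5 to 1.9.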

Compound 4, distribution coefficient: 2
Beside the measured number, compound 4's estimate is 0.80 log units below it; measured number outside the range, above it.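

In this assay, among these compounds, methylsulfonyl in place of carbamoyl on a saturated chain carbon, two bonds along the chain from an amide-type nitrogen and a carbonyl carbon, gives a number 1.00 log units higher from compound 1 to compound 4 (beyond the scatter) and so provides the only comparison here of two compounds that differ in one place. It shows that the read-out at this position responds to the group exchanged. Carbamoyl brings a hydrogen-bond donor that methylsulfonyl lacks, and the exchange also alters the heavy atoms and acceptors, but nothing shown separates these differences or gives a cause for the step.

Still open, on these data alone, is how a carboxylic acid, an amine or a longer chain ending in carbamoyl would read at this carbon. Also open, as far as these compounds go, is whether this step would hold on a different core.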